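A Bromo for Methyl Swap on Compound 2

The source may hold more compounds than are shown below. What is called first, only, known or untested is meant among the compounds shown, and "the series" means these compounds.

Compound 1 `O=C1/C(=C/c2cccnc2)CNC/C1=C\c1ccccc1C(F)(F)F`: 5100 nM
Compound 2 `Cc1ccc(S(=O)(=O)N2C/C(=C\c3cccnc3)C(=O)/C(=C/c3ccccc3C(F)(F)F)C2)cc1`: 6700 nM

Within the data shown here, in a functional assay on SMMC-7721 cells (Homo sapiens) for cytotoxicity, read by MTT assay, with a stated time of 24 h (on this read-out higher numbers stand for weaker inhibition and lower numbers for stronger inhibition), compound 2 reads 6700 nM, which lies within the scatter of compound 1, the only other compound measured so far. The next compound to be tested, compound 3 `O=C1/C(=C/c2cccnc2)CN(S(=O)(=O)c2ccc(Br)cc2)C/C1=C\c1ccccc1C(F)(F)F`, keeps everything in compound 2 except one group: bromo in place of methyl on an aromatic carbon. In words, this is bromo in place of methyl on an aromatic carbon, so that (4-methylphenyl)sulfonyl becomes (4-bromophenyl)sulfonyl.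

Among the measured compounds shown here, only one measured step bears on this change, and it does so indirectly. That step, a 1.3-fold higher number from compound 1 to compound 2 (0.12 log units; within the scatter), put the whole (4-methylphenyl)sulfonyl group in place of hydrogen on the amine nitrogen. Even this much larger change stayed within the scatter. For the measured compounds named here, no measured pair varies the group on the aromatic ring itself, so the data offer no direct guide to the swap. A single-atom exchange at that site is therefore expected to give no shift beyond the scatter, in either direction. The expected step is a 1.1-fold lower number from compound 2 to compound 3 (0.05 log units; within the scatter). For compound 3 the estimated value is 6000 nM, with an expected range from 3000 nM to 12000 nM.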

Compound 3, half-maximal inhibitory concentration: 5760 nM
Estimate against measurement, compound 3: 1.0-fold (0.02 log units) above; low and high end bracket the measured number.
By their numbers in this assay, from the lowest: compounds 1, 3 and 2 (each within the scatter of the next).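

In this assay, among these compounds, the step of a 1.2-fold lower number from compound 2 to compound 3 (0.07 log units; within the scatter) is the first direct test of this site, and it shows that exchanging methyl for bromo on an aromatic carbon, para to a large group, does not move the read-out beyond the scatter. The nitrogen change now has a second example: a 1.1-fold higher number from compound 1 to compound 3 (0.05 log units; within the scatter) stands with a 1.3-fold higher number from compound 1 to compound 2 (0.12 log units; within the scatter), and both lie within the scatter, so neither (4-bromophenyl)sulfonyl nor (4-methylphenyl)sulfonyl in place of hydrogen separates from compound 1 on this read-out. Nothing on hand offers an explanation for these readings.

As far as these compounds go, only methyl and bromo have been seen at this site, so it remains open whether a group of another kind there, such as a carboxylic acid, an amine or a longer alkyl chain, would give a step beyond the scatter. All three compounds also share the rest of the core and a single cell read-out, so the compounds shown say nothing about changes elsewhere on the core, or about whether this flat result would hold in another test.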